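Notes on the aryl-triazole series: cyano for methyl

The compounds below may be only part of what the source reports. "The series", "measured", "known", "first", "only" and "open" are said of these compounds alone.

Measured so far in a functional assay on OVCAR-3 cells (Homo sapiens) for inhibition, read by MTT assay, with a stated time of 24 h; on this read-out lower numbers stand for stronger inhibition and higher numbers for weaker inhibition:
Compound 1, `Cc1ccccc1-n1cc(CN2C(=O)C[C@@H]3CC[C@@]2(C)C3(C)C)nn1`: compound 1 gives 150 nM.
Compound 2, `Cc1ccc(-n2cc(CN3C(=O)C[C@@H]4CC[C@@]3(C)C4(C)C)nn2)cc1`: compound 2 gives 40 nM.
Compound 3, `CC1(C)[C@H]2CC[C@]1(C)N(Cc1cn(-c3ccccc3)nn1)C(=O)C2`: compound 3 gives 50 nM.

Compound 1 carries the highest number of the three. Moving the methyl across the ring gives a 3.8-fold lower number from compound 1 to compound 2 (0.57 log units; beyond the scatter), and removing it altogether gives a 3.0-fold lower number from compound 1 to compound 3 (0.48 log units; beyond the scatter); compounds 2 and 3 themselves lie within the scatter of each other, a 1.3-fold higher number from compound 2 to compound 3 (0.10 log units; within the scatter).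

Compound 4, `CC1(C)[C@H]2CC[C@]1(C)N(Cc1cn(-c3ccccc3C#N)nn1)C(=O)C2`, is built from compound 1 by the change (cyano in place of methyl on an aromatic carbon). Among the compounds with values here, no measured step involves cyano, so the nearest guidance is indirect: both measured steps that touch the same methyl on compound 1 lowered the number by a modest amount. From the compounds shown here alone, it is therefore expected that replacing that methyl brings compound 4 toward the region of compounds 2 and 3, with a modest lowering, a 1.9-fold lower number from compound 1 to compound 4 (0.27 log units; within the scatter), though the cyano itself is untested and the range is kept wide. Compound 4 is estimated at 80 nM, between 30 nM and 250 nM.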

Compound 4, half-maximal inhibitory concentration: 110 nM
Beside the measured number, compound 4's estimate is 1.4-fold (0.14 log units) below it; low and high end bracket the measured number.
By their numbers in this assay, from the lowest: compounds 2 and 3 (each within the scatter of the next); then compounds 4 and 1 (each within the scatter of the next).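

In this assay, cyano at this place, on an aromatic carbon ortho to a large group, cannot be told apart from methyl: a 1.4-fold lower number from compound 1 to compound 4 (0.13 log units; within the scatter). Both of these 2-substituted phenyl compounds sit apart from the unsubstituted phenyl and the 4-methylphenyl compounds, with a 2.2-fold higher number from compound 3 to compound 4 (0.34 log units; beyond the scatter) and a 2.8-fold higher number from compound 2 to compound 4 (0.44 log units; beyond the scatter), so among the compounds shown, the gain seen on leaving the 2-methylphenyl group does not carry over to a swap of methyl for cyano at the same place. The data at hand offer no explanation for this.

Open, from the compounds shown here alone, is whether an amine or a methoxy group at this place would stay with compound 1 or reach the level of compound 3. Also open, going by these compounds, is how cyano would behave at the ring position that holds the methyl in compound 2.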